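Replacing Chloro with Hydroxypiperidinyl on Compound 3

The source may hold more compounds than are shown below. What is called first, only, known or untested is meant among the compounds shown, and "the series" means these compounds.

The measured compounds and their values:

Compound 1 `CCC(=O)N1N=C(C)CC1c1cc(Br)cc(Br)c1O` gives 28600 nM.
Compound 2 `CC1=NN(C(=O)c2ccc(C)cc2)C(c2cc(Br)cc(Br)c2O)C1` gives 41200 nM.
Compound 3 `O=C(CCl)N1N=C(c2cc3ccccc3oc2=O)CC1c1ccccc1` gives 2980 nM.

These three compounds were tested in a functional assay on PC-3 cells (Homo sapiens) for cytotoxicity, read by MTT assay, with a stated time of 48 h; on this read-out higher numbers stand for weaker inhibition and lower numbers for stronger inhibition. Compound 3 stands lowest of the three numbers. Compound 1, with its number beyond the scatter above compound 3, is the nearest of the other two, and compound 2 is the furthest. Among the compounds with values here, the one step between measured compounds, a 1.4-fold higher number from compound 1 to compound 2 (0.16 log units; within the scatter), lies within the scatter and concerns the carbonyl substituent on a core that compound 3 does not share.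

Compound 4 `O=C(CN1CCC(O)CC1)N1N=C(c2cc3ccccc3oc2=O)CC1c1ccccc1` differs from compound 3 in one place: 4-hydroxypiperidin-1-yl in place of chloro on a saturated chain carbon bound to a carbonyl carbon. Within the data shown here, no measured step touches this position, and no measured pair shows what the chloro contributes to the number of compound 3. Among the measured compounds shown here, the only information is the step from compound 1 to compound 2, which changed another part of another core and stayed within the scatter. On that thin basis, compound 4 is expected to give 6000 nM in this assay, within the range 1500 nM to 25000 nM. This means an expected step of a 2.0-fold higher number from compound 3 to compound 4 (0.30 log units; within the scatter), a modest weakening that may or may not exceed the scatter.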

Compound 4, half-maximal inhibitory concentration: "not active" (no number reported)
Compound 4: no number reported, and the estimate cannot be compared.
By their numbers in this assay, from the lowest: compound 3; then compounds 1 and 2 (each within the scatter of the next).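

In this assay compound 4 is reported as not active with no number, so no step can be read from compound 3 at 2980 nM to compound 4. No evidence bears on this result. The compounds shown leave open what the chloro contributes and how far 4-hydroxypiperidin-1-yl in its place moves the number.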